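Benzyl ether variation and distribution volume in rat

The source may hold more compounds than are shown below. What is called first, only, known or untested is meant among the compounds shown, and "the series" means these compounds.

Compound 1 `O=C(O)c1cccc(C2=C(c3cc(Br)ccc3OCc3ccc(F)cc3)CCC2)c1` and compound 2 `O=C(O)c1cccc(C2=C(c3cc(Br)ccc3OCc3ccc(Cl)cc3)CCC2)c1` share one core and differ in one place. In an in vivo ADME assay on the whole organism for pharmacokinetics, with Rattus norvegicus as the target, at a dose of 1 mg/kg by the intravenous route (a lower number here means that more of the compound stays in the plasma, a higher number that more of the compound sits outside the plasma), compound 1 gives 0.7 L/kg and compound 2 gives 0.4 L/kg. Going by the values given here, the step of a 1.8-fold lower number from compound 1 to compound 2 (0.24 log units; within the scatter) separates them only within the scatter, so compound 2 cannot be set apart from compound 1 on the numbers so far. Compound 3 `O=C(O)c1cccc(C2=C(c3cc(Br)ccc3OCc3ccc(F)cc3F)CCC2)c1` carries 2,4-difluorophenyl in place of 4-chlorophenyl on a saturated chain carbon bound to an oxygen on an aromatic ring. Among the compounds with values here, the only step that bears on this change is the one from compound 1 to compound 2, and it stayed within the scatter. For compound 3 the expectation is therefore no shift beyond the scatter in this assay, a step of a 1.3-fold higher number from compound 2 to compound 3 (0.10 log units; within the scatter). Compound 3 is estimated at 0.5 L/kg, with a range from 0.3 L/kg to 1 L/kg.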

Compound 3, volume of distribution at steady state: 0.6 L/kg
For compound 3 the middle estimate is 1.2-fold (0.08 log units) below the measured one, within the range that was stated.
By their numbers in this assay, from the lowest: compounds 2, 3 and 1 (each within the scatter of the next).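

In this assay the three benzyl ethers now form a set whose steps all stay within the scatter: a 1.5-fold higher number from compound 2 to compound 3 (0.18 log units; within the scatter) for 2,4-difluorophenyl in place of 4-chlorophenyl, and a 1.2-fold lower number from compound 1 to compound 3 (0.07 log units; within the scatter) for fluoro in place of hydrogen on an aromatic carbon. Neither exchange of halogen pattern on this ring sets compound 3 apart from compound 1 or compound 2. No evidence on the cause is available here. Open, going by these compounds, is whether an amine or a carboxylic acid on this ring, or a longer chain in place of the benzyl carbon, gives a step beyond the scatter.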